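Swapping the base of a bicyclic nucleoside analogue

A few compounds are considered here, and "the series" means these few. Any claim that something is new, unique, unknown or untested is made for them only; others in the source may bear on it.

Measured compounds:
- compound 1 `CN(C)c1ncnc2c1ncn2[C@@H]1O[C@H](CO[Si](C)(C)C(C)(C)C)[C@@]2(OS(=O)(=O)C=C2N)[C@H]1O[Si](C)(C)C(C)(C)C`: 15000 nM
- compound 2 `Cn1cnc2c(ncn2[C@@H]2O[C@H](CO[Si](C)(C)C(C)(C)C)[C@@]3(OS(=O)(=O)C=C3N)[C@H]2O[Si](C)(C)C(C)(C)C)c1=O`: the result is a limit, > 150000 nM
- compound 3 `CC(C)(C)[Si](C)(C)OC[C@H]1O[C@@H](n2cnc3c(N)ncnc32)[C@H](O[Si](C)(C)C(C)(C)C)[C@]12OS(=O)(=O)C=C2N`: 13000 nM

In a functional assay on MT4 cells (Homo sapiens) for cytotoxicity (on this read-out higher numbers stand for lower toxicity in this test and lower numbers for higher toxicity in this test), compound 3 gives 13000 nM, the lowest of the two numbers reported; its nearest neighbour is compound 1, whose value sits within the scatter of it, so the two cannot be told apart. For compound 2 this assay reports only a limit, > 150000 nM.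

Compound 4 `CC(C)(C)[Si](C)(C)OC[C@H]1O[C@@H](n2cnc3ccccc32)[C@H](O[Si](C)(C)C(C)(C)C)[C@]12OS(=O)(=O)C=C2N` differs from compound 3 in the base attached to the sugar-like core: a group of 9 heavy atoms (7 carbon, 2 nitrogen; one five-membered aromatic ring with 2 hetero atoms, one six-membered aromatic ring of carbon only) in place of a group of 10 heavy atoms (5 carbon, 5 nitrogen; one five-membered aromatic ring with 2 hetero atoms, one six-membered aromatic ring with 2 hetero atoms), on a saturated ring carbon.

For the measured compounds named here, no measured step swaps a base for one lacking ring nitrogens in the six-membered ring, so the comparison rests on the other base exchanges. From compound 1 to compound 2 the number rose, an at least 10-fold higher number from compound 1 to compound 2 (1.00 log units; beyond the scatter), while from compound 2 to compound 3 it fell again, an at least 11-fold lower number from compound 2 to compound 3 (1.06 log units; beyond the scatter). Changing only the amino substituent left the number essentially unchanged, a 1.2-fold lower number from compound 1 to compound 3 (0.06 log units; within the scatter). Base exchanges can therefore shift this read-out well beyond the scatter in either direction, whereas small edits do not.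

For compound 4 a modest rise in this assay is expected, a 2.3-fold higher number from compound 3 to compound 4 (0.36 log units; beyond the scatter), giving an estimated 30000 nM with a range from 8000 nM to 150000 nM; a limit result like that of compound 2 cannot be excluded.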

Compound 4, half-maximal cytotoxic concentration: 15000 nM
Compound 4: middle estimate off by 2.0-fold (0.30 log units), on the high side; measured number inside the range.
By their numbers in this assay, from the lowest: compounds 3, 1 and 4 (each within the scatter of the next). At a limit, above all of these: compound 2.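

In this assay, the 1H-benzimidazol-1-yl base gives up both the amino group and the nitrogens of the six-membered ring, yet the result cannot be told apart from the adenine-type base of compound 3: a 1.2-fold higher number from compound 3 to compound 4 (0.06 log units; within the scatter). The same holds against the dimethylamino base, no change at the digits printed from compound 1 to compound 4 (within the scatter), so for these three compounds neither those ring nitrogens nor an amino substituent is needed to reach this level of toxicity in the test. Compound 2 is the one that goes against this grouping, an at least 10-fold lower number from compound 2 to compound 4 (1.00 log units; beyond the scatter), and its result is a limit, not a number: the limit of > 150000 nM in this assay, at which 1 of the 4 values shown sits.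

The compounds shown do not separate the carbonyl of compound 2 from its ring methyl, so a benzimidazole carrying a carbonyl or a methyl group on its six-membered ring would be an informative test of which feature goes with the limit result. Going by these compounds, all four compounds also share the same tert-butyldimethylsilyl groups on the core, so it remains open how the numbers would stand with free hydroxyl groups in their place.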